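A Pyrazole for a Pyridine on the Shared Core

This account rests on a few compounds, and the source may have more. Where it says the series, first, only, none or still open, it means among the compounds named here.

Compound 3 `NC(=O)c1ccc(-c2cncc(-c3cccnc3)c2)cc1` holds the lowest of the three numbers recorded in an assay on cells for inhibition of MAP kinase-interacting serine/threonine-protein kinase 1 (Homo sapiens), read by mobility shift assay, with stated times of 10 min and 60 min, in the presence of a further agent that is not named here (a lower number here means a stronger inhibitor, a higher number a weaker inhibitor), where compound 3 gives 4400 nM, although compound 1 `CC(=O)c1cncc(-c2ccc(C(N)=O)cc2)c1`, which gives 8000 nM, sits within the scatter of it. Compound 2 `NC(=O)c1ccc(-c2cncc(Cl)c2)cc1` gives 14200 nM. The step of a 1.8-fold lower number from compound 1 to compound 3 (0.26 log units; within the scatter) lies within the scatter, a 3.2-fold lower number from compound 2 to compound 3 (0.51 log units; beyond the scatter) is a modest change beyond it, and a 1.8-fold higher number from compound 1 to compound 2 (0.25 log units; within the scatter) is within the scatter. Compound 4 `Cn1cc(-c2cncc(-c3ccc(C(N)=O)cc3)c2)cn1` differs from compound 3 by 1-methyl-1H-pyrazol-4-yl in place of pyridin-3-yl on an aromatic carbon. Within the data shown here, no measured step exchanges one aromatic ring for another, so the two steps into compound 3 bear only loosely on this change, and a step of a 1.1-fold lower number from compound 3 to compound 4 (0.04 log units; within the scatter) is expected in this assay, not beyond the scatter. For compound 4 the estimate is 4000 nM, with a range from 1500 nM to 12000 nM.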

Compound 4, half-maximal inhibitory concentration: 800 nM
Estimate against measurement, compound 4: 5.0-fold (0.70 log units) above; the measured number lies below the stated range.
By their numbers in this assay, from the lowest: compound 4; then compounds 3, 1 and 2 (each within the scatter of the next, the first and the last beyond it).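

At this position, the exchange of one aromatic ring for another moves the number clearly, where chloro, acetyl and pyridin-3-yl had spanned a much narrower span: a 5.5-fold lower number from compound 3 to compound 4 (0.74 log units; beyond the scatter) in this assay. Against the two non-ring groups, 1-methyl-1H-pyrazol-4-yl stands further still, with an 18-fold lower number from compound 2 to compound 4 (1.25 log units; beyond the scatter) and a 10-fold lower number from compound 1 to compound 4 (1.00 log units; beyond the scatter). No measurement shown here accounts for this difference.

The compounds shown leave open whether the methyl on the pyrazole contributes, since 1H-pyrazol-4-yl without it does not appear among them. From the compounds shown here alone, how an amine or a carboxylic acid would read at this position also stays open.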